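The source may hold more compounds than are shown below. What is called first, only, known or untested is meant among the compounds shown, and "the series" means these compounds.

Measured so far:
- Compound 1 `COc1ccc(-c2c(CNC(C)(C)C)c(C(=O)O)nn2-c2ccccc2)cc1`: > 659000 nM (a limit)
- Compound 2 `Cc1ccc(-c2c(CNC(C)(C)C)c(C(=O)O)nn2-c2ccc(Cl)cc2)cc1`: > 629000 nM (a limit)

In a functional assay on MCF7 cells (Homo sapiens) for inhibition, read by sulforhodamine B assay, with a stated time of 48 h (a lower number here means a stronger inhibitor of growth, a higher number a weaker inhibitor of growth), compound 2 has no numerical value, only the limit > 629000 nM. Compound 1 is also known only by a limit, > 659000 nM. Compound 3 `COc1ccc(-c2c(CNC(C)(C)C)c(C(=O)O)nn2-c2ccc(Cl)cc2)cc1` carries methoxy in place of methyl on an aromatic carbon, para to a large group: methoxy in place of methyl on an aromatic carbon. Going by the values given here, no measured step covers this change, so no shift beyond the usual scatter is expected in this assay, in either direction. The expected step is an at least 1.0-fold lower number from compound 2 to compound 3 (0.00 log units; that floor lies within the scatter). For compound 3, the estimated value is 620000 nM, with an expected range of 300000 nM to 1000000 nM.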

Compound 3, concentration for 50% growth inhibition: 220000 nM
The estimate for compound 3 lay 2.8-fold (0.45 log units) above the measured number; the measured number lies below the stated range.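

In this assay methoxy in place of methyl on an aromatic carbon, para to a large group, gives an at least 2.8-fold lower number from compound 2 to compound 3 (0.45 log units; beyond the scatter) and so shows that this position answers to the change. With the methoxy kept, chloro in place of hydrogen on an aromatic carbon gives an at least 2.9-fold lower number from compound 1 to compound 3 (0.47 log units; beyond the scatter) as a second step. Compound 3, which carries both groups, is the only one of the three with a number rather than a limit. Going by these compounds, both steps are floors, so their full size stays open. On these data alone, whether a hydroxyl, an amine or an ethoxy at this position would shift the number further also stays open.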